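This account rests on a few compounds, and the source may have more. Where it says the series, first, only, none or still open, it means among the compounds named here.

Measured in a functional assay on HEK293 cells for antagonist activity at transient receptor potential cation channel subfamily V member 1 (Rattus norvegicus), read by calcium flux; a higher number here means a weaker inhibitor, a lower number a stronger inhibitor:
compound 1 `Clc1cccc(Cl)c1Nc1nc2c(Nc3ccccc3)ncnc2s1` gives 170 nM
compound 2 `Cc1ccc(Nc2ncnc3sc(Nc4c(Cl)cccc4Cl)nc23)cc1` gives 32 nM
compound 3 `FC(F)(F)c1ccc(Nc2ncnc3sc(Nc4c(Cl)cccc4Cl)nc23)cc1Cl` gives 9 nM

Compound 2 differs from compound 1 by methyl in place of hydrogen on an aromatic carbon; in this assay this reads a 5.3-fold lower number from compound 1 to compound 2 (0.73 log units; beyond the scatter). Compound 3 gives the lowest of the three numbers, and its gaps to compound 2 and to compound 1 both lie beyond the scatter. How the core of compound 3 differs from compound 1 is not broken down here.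

Compound 4 `Cc1nc(Nc2ccc(C(F)(F)F)c(Cl)c2)c2nc(Nc3c(Cl)cccc3Cl)sc2n1` is not yet measured. It differs from compound 3 by methyl in place of hydrogen on an aromatic carbon. Among the compounds with values here, this is the same kind of change as the one from compound 1 to compound 2, but not the same: in compound 2 the methyl enters on a six-membered aromatic ring of carbon only, para to a large group, whereas in compound 4 it enters on a six-membered aromatic ring with 2 nitrogen, part of a fused or bridged system of two rings, between two ring nitrogen atoms, meta to a fused ring, meta to a large group, para to a fused ring. Within the data shown here, the only precedent for a methyl entering in place of hydrogen is a 5.3-fold lower number from compound 1 to compound 2 (0.73 log units; beyond the scatter), and that precedent sits on a different ring in a different surrounding, so it carries limited weight for compound 4. The expected step is a 1.3-fold higher number from compound 3 to compound 4 (0.12 log units; within the scatter), taken as smaller than the earlier one and with wide uncertainty in both directions. Compound 4 is estimated at 12 nM, with a range from 3 nM to 45 nM.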

Compound 4, half-maximal inhibitory concentration: 2 nM
Compound 4: middle estimate off by 6.0-fold (0.78 log units), on the high side; the whole stated range lies above it.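

In this assay, methyl in place of hydrogen on the six-membered aromatic ring with 2 nitrogen, between two ring nitrogen atoms, gives a 4.5-fold lower number from compound 3 to compound 4 (0.65 log units; beyond the scatter), a step clearly larger than the usual scatter. Within the data shown here, although the methyl enters on a different ring and in a different surrounding from the earlier case, the two steps match in direction and do not differ in size: the same change on two cores in this assay, a 5.3-fold lower number (0.73 log units; beyond the scatter) from compound 1 to compound 2 and a 4.5-fold lower number (0.65 log units; beyond the scatter) from compound 3 to compound 4, 1.2-fold (0.07 log units) apart, within the scatter of two such steps This shows that a methyl in place of hydrogen lowered the number on both cores, but it rests on only two pairs, with a different site in each, so it does not establish a rule for other aromatic carbons or other cores, and it gives no cause for the match in size.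

The compounds shown leave open whether the methyl on the ring with 2 nitrogen would give a step of similar size on the core of compound 1, and whether a methyl on the carbon-only ring would do so on the core of compound 3. Also open, going by these compounds, is whether a longer chain such as ethyl, or an amine, at the carbon between the two ring nitrogen atoms would lower the number as methyl does.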